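The compounds below may be only part of what the source reports. "The series", "measured", "known", "first", "only" and "open" are said of these compounds alone.

Going by the values given here, compound 1 (`COc1cc2c(/C=C3/C(=O)Nc4ccc(O)cc43)c(Cl)n(Cc3cc(OC)c(OC)c(OC)c3)c2cc1C`) is one of three compounds measured in a functional assay on cells (Cancer cell lines, Homo sapiens) for cytotoxicity, with a stated time of 48 h (on this read-out higher numbers stand for weaker inhibition of growth and lower numbers for stronger inhibition of growth), where compound 1 gives 34700 nM. Compound 2 (`O=C1Nc2ccccc2/C1=C\c1c(Cl)n(Cc2ccccc2)c2ccccc12`) gives 64600 nM in this assay, and compound 3 (`O=C1/C(=C/c2c(Cl)[nH]c3ccccc23)c2ccccc2N1Cc1ccccc1`) gives 56200 nM. Compound 1 has the lowest of the three numbers, yet all three values lie within the usual scatter of one another, so no order among them can be read from these data.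

Compound 4 (`COc1cc2c(/C=C3/C(=O)Nc4cccc(Cl)c43)c(Cl)n(Cc3cc(OC)c(OC)c(OC)c3)c2cc1C`) differs from compound 1 by a group of 12 heavy atoms (9 carbon, 1 nitrogen, 1 oxygen, 1 chlorine; one five-membered non-aromatic ring with 1 hetero atom, one six-membered aromatic ring of carbon only) in place of a group of 12 heavy atoms (9 carbon, 1 nitrogen, 2 oxygen; one five-membered non-aromatic ring with 1 hetero atom, one six-membered aromatic ring of carbon only), on an aromatic carbon. Among the compounds with values here, no measured pair shows this kind of change, so there is no direct guide to its size. Because compound 1 gives 34700 nM in this assay and the two other measured values lie within the scatter of that number, compound 4 is expected to stay near it, with the estimated step being a 1.2-fold lower number from compound 1 to compound 4 (0.06 log units; within the scatter). The estimated value for compound 4 in this assay is 30000 nM, with a likely range from 10000 nM to 90000 nM.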

Compound 4, concentration for total growth inhibition: 15100 nM
The estimate for compound 4 lay 2.0-fold (0.30 log units) above the measured number; measured number inside the range.
By their numbers in this assay, from the lowest: compound 4; then compounds 1, 3 and 2 (each within the scatter of the next).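

In this assay, going by these compounds alone, the change on this aromatic carbon gives a 2.3-fold lower number from compound 1 to compound 4 (0.36 log units; beyond the scatter) and is the first difference in this set to lie beyond the usual scatter. This shows that exchanging the large group here can shift the number modestly, with a chlorine entering and an oxygen leaving, along with fewer hydrogen-bond donors and acceptors. No measurement shown explains the shift.

On these data alone, this single step changes these features together, so their separate contributions stay unknown. As far as these compounds go, how a fluorine, a methyl or an amine in place of the chlorine would behave also remains open.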